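From a Diethylamino to a Piperidine Side Chain

The source may report more compounds than this note shows. Statements on the series, on what has been measured and on what is new or still open speak of the compounds shown alone.

Measured in a functional assay on HepG2 cells (Homo sapiens) for antiproliferative activity, read by MTT assay, with a stated time of 72 h; a lower number here means a stronger inhibitor, a higher number a weaker inhibitor:
- Compound 1 `O=C(N/N=C/c1cccc(Cl)c1Cl)Nc1ccc(Oc2ccnc3[nH]ccc23)cc1` gives "not active" (no number reported)
- Compound 2 `CCN(CC)CCn1cccc1/C=N/NC(=O)Nc1ccc(Oc2ccnc3[nH]ccc23)cc1` gives 5880 nM
- Compound 3 `CCN(CC)CCCn1cccc1/C=N/NC(=O)Nc1ccc(Oc2ccnc3[nH]ccc23)c(F)c1` gives 2140 nM

Of the two compounds with a number, compound 2 stands higher, at 5880 nM, which makes it the weaker inhibitor of the pair. Compound 3 follows at 2140 nM, a gap beyond the usual scatter. Compound 1 offers no number for comparison.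

The next compound is compound 4 `O=C(N/N=C/c1cccn1CCCN1CCCCC1)Nc1ccc(Oc2ccnc3[nH]ccc23)cc1`, which differs from compound 2 as follows: (piperidin-1-yl)methyl in place of diethylamino on a saturated chain carbon, two bonds along the chain from an aromatic nitrogen. Put in words, (piperidin-1-yl)methyl stands in place of diethylamino on a saturated chain carbon, two bonds along the chain from an aromatic nitrogen.

Going by the values given here, no pair of measured compounds isolates this change, so any forecast is loose. A modest shift toward a lower number in this assay is expected, close to the edge of the scatter, and the expected move is a 1.8-fold lower number from compound 2 to compound 4 (0.25 log units; within the scatter). Compound 4 is estimated at 3300 nM, with an expected range from 1100 nM to 10000 nM.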

Compound 4, half-maximal inhibitory concentration: 3690 nM
For compound 4 the middle estimate is 1.1-fold (0.05 log units) below the measured one; measured number inside the range.
By their numbers in this assay, from the lowest: compounds 3, 4 and 2 (each within the scatter of the next, the first and the last beyond it).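

In this assay, going by these compounds alone, replacing 2-(diethylamino)ethyl with 3-(piperidin-1-yl)propyl gives a 1.6-fold lower number from compound 2 to compound 4 (0.20 log units; within the scatter), the first step that can be read at this position. The side chain can therefore take a six-membered non-aromatic ring with one hetero atom, together with the change of chain, and the two compounds remain within the scatter of each other. Because this single step alters the ring and the chain together, it does not show what either change does alone, and any effects that cancel each other would stay hidden.

From the compounds shown here alone, whether a 2-(piperidin-1-yl)ethyl side chain, or a morpholine ring in place of the piperidine, would stay within the same scatter remains open. Nothing measured here gives a reason for this result.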